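The source may hold more compounds than are shown below. What is called first, only, known or untested is meant among the compounds shown, and "the series" means these compounds.

Working notes on the series. Three compounds have been run in a functional assay on U2OS cells (Homo sapiens) for antiproliferative activity, read by MTT assay, with a stated time of 72 h; a higher number here means a weaker inhibitor, a lower number a stronger inhibitor: compound 1, `CC(C)OC1=C(C(=O)c2ccccc2)C(c2ccc(Br)cc2)N(CCCn2ccnc2)C1=O`, compound 2, `CCCCCOC1=C(C(=O)c2ccccc2)C(c2ccc(Br)cc2)N(CCCn2ccnc2)C1=O`, and compound 3, `O=C(C1=C(Nc2ccccc2)C(=O)N(CCCn2ccnc2)C1c1ccc(Br)cc1)c1ccccc1`. In this assay compound 1 gives 24800 nM, compound 2 gives 9140 nM and compound 3 gives 25700 nM. Compound 2 holds the lowest number of the three; a 2.7-fold lower number from compound 1 to compound 2 (0.43 log units; beyond the scatter) and a 2.8-fold higher number from compound 2 to compound 3 (0.45 log units; beyond the scatter) set it apart from the other two, whereas a 1.0-fold higher number from compound 1 to compound 3 (0.02 log units; within the scatter) leaves compound 1 and compound 3 indistinguishable.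

Compound 4, `O=C(C1=C(Nc2ccc(I)cc2)C(=O)N(CCCn2ccnc2)C1c1ccc(Br)cc1)c1ccccc1`, differs from compound 2 as follows: (4-iodophenyl)amino in place of pentyloxy on a double-bonded ring carbon. Among the measured compounds shown here, two measured steps bear on this change. a 2.8-fold higher number from compound 2 to compound 3 (0.45 log units; beyond the scatter) exchanges the same pentyloxy for a plain anilino, and a 1.0-fold higher number from compound 1 to compound 3 (0.02 log units; within the scatter) shows the anilino level with isopropoxy. For the measured compounds named here, no measured compound carries an iodine on the entering ring, so that part of the change is unsupported by data. The expected outcome is a step of the size seen toward compound 3, namely a 2.4-fold higher number from compound 2 to compound 4 (0.38 log units; beyond the scatter) in this assay. Compound 4 is accordingly estimated at 22000 nM, with a range from 8000 nM to 60000 nM.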

Compound 4, half-maximal inhibitory concentration: 12000 nM
For compound 4 the middle estimate is 1.8-fold (0.26 log units) above the measured one, within the range that was stated.
By their numbers in this assay, from the lowest: compounds 2 and 4 (each within the scatter of the next); then compounds 1 and 3 (each within the scatter of the next).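

In this assay, among the compounds shown here, the iodo group gives the first change on the entering ring at this position, a 2.1-fold lower number from compound 3 to compound 4 (0.33 log units; beyond the scatter), so this ring can shift the value even though the plain anilino sat level with isopropoxy. The (4-iodophenyl)amino group also separates from isopropoxy, a 2.1-fold lower number from compound 1 to compound 4 (0.32 log units; beyond the scatter), while the exchange for pentyloxy stays within the scatter, a 1.3-fold higher number from compound 2 to compound 4 (0.12 log units; within the scatter), so an anilino-type group on this double-bonded ring carbon can reach the level of the pentyloxy compound once it carries iodine. No measured evidence on hand accounts for the gain from iodine.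

Still open, as far as these compounds go, is whether the gain is particular to iodine, which a chloro or methoxy group in its place would test. A pentylamino group on the same ring carbon would show whether the linking nitrogen or the chain carries the result.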